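Changing the aryl amide at the chain end

A few compounds are considered here, and "the series" means these few. Any claim that something is new, unique, unknown or untested is made for them only; others in the source may bear on it.

Compound 1, `Cn1c(Cc2nn(C)c(=O)c3ccccc23)nnc1SCCCCCCCC(=O)Nc1ccc(Br)cc1Br`: 1500 nM
Compound 2, `Cn1c(Cc2nn(C)c(=O)c3ccccc23)nnc1SCCCCCCCCCCC(=O)Nc1ccccc1Cl`: 15000 nM
Compound 3, `Cn1c(Cc2nn(C)c(=O)c3ccccc23)nnc1SCC(=O)Nc1ccc(I)cc1`: "not active" (no number reported)

In an assay on isolated protein (Mus musculus) for inhibition of IL15-IL15 receptor (Homo sapiens), read by resazurin assay, with stated times of 30 min and 2.5 days (a lower number here means a stronger inhibitor, a higher number a weaker inhibitor), compound 1 gives 1500 nM, the lowest of the two numbers measured. Compound 2 gives a higher number, a gap beyond the scatter. Compound 3, which carries a 4-iodophenyl on a short chain, is reported only as not active, with no number. Compound 4, `Cn1c(Cc2nn(C)c(=O)c3ccccc23)nnc1SCCCCCCCC(=O)Nc1ccc(I)cc1`, keeps the long chain of compound 1 but differs in one place: 4-iodophenyl in place of 2,4-dibromophenyl on an amide-type nitrogen. Among the measured compounds shown here, no measured pair shows this change directly, so its size is open. Given that compound 3 with the same 4-iodophenyl gives no number, the step of a 3.3-fold higher number from compound 1 to compound 4 (0.52 log units; beyond the scatter) is expected to weaken inhibition beyond the scatter. Compound 4 is therefore estimated at 5000 nM, within 1200 nM to 25000 nM.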

Compound 4, half-maximal inhibitory concentration: 1300 nM
For compound 4 the middle estimate is 3.8-fold (0.59 log units) above the measured one, within the range that was stated.
By their numbers in this assay, from the lowest: compounds 4 and 1 (each within the scatter of the next); then compound 2.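

In this assay, placing 4-iodophenyl instead of 2,4-dibromophenyl on the amide-type nitrogen gives a 1.2-fold lower number from compound 1 to compound 4 (0.06 log units; within the scatter), so on this long chain the two aryl groups cannot be told apart. The same 4-iodophenyl gives a number in compound 4, whereas compound 3, with its short chain, is reported as not active. Nothing measured here explains why the two groups match.

From the compounds shown here alone, whether plain phenyl, or a phenyl carrying an amine or a carboxylic acid, would give a similar number remains open. So does how 4-iodophenyl behaves on a longer chain.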